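A few compounds are considered here, and "the series" means these few. Any claim that something is new, unique, unknown or untested is made for them only; others in the source may bear on it.

Compound 1 `C=C[C@@](C)(/C=C/c1ccc(O)c(C=O)c1)CCC=C(C)C`: in an ADME assay on BJ cells (Homo sapiens) for cytotoxicity, with a stated time of 72 h (a higher number here means that more compound is needed for the effect, a lower number that less compound is needed), compound 1 gives > 36600 nM, which is a limit of the assay rather than a number.
Compound 2 `C=C[C@@](C)(/C=C/c1ccc(O)c(/C=C/C(=O)OCC)c1)CCC=C(C)C`: in this assay compound 2 gives > 36600 nM, again only a limit of the assay.

Compound 2 therefore stands at the edge of what the assay can read, since the limit of > 36600 nM in this assay, at which 2 of the 2 values shown sit, covers every value shown. Going by the values given here, the one measured step, a step that the two limits leave unreadable from compound 1 to compound 2, cannot be read because the limit of > 36600 nM in this assay, at which 2 of the 2 values shown sit, holds both of its ends. Compound 3 `C=C[C@@](C)(/C=C/c1ccc(O)c(/C=C/c2ccc(Cl)c(Cl)c2)c1)CCC=C(C)C` differs from compound 2 by 3,4-dichlorophenyl in place of ethoxycarbonyl on a double-bonded chain carbon bound to a double-bonded chain carbon. Among the compounds with values here, no measured step bears on this change in a readable way, so the step is expected to be a step that the limit leaves unreadable from compound 2 to compound 3, with nothing beyond the scatter foreseeable. Compound 3 is estimated at 40000 nM, in a range from 12000 nM to 120000 nM, and most likely the assay again reports only a limit.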

Compound 3, half-maximal effective concentration: > 13000 nM
Compound 3 gave a limit, no number (the forecaster's own chance of this, stated with the estimate: 70%); the middle value does not contradict the limit.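

Compound 2 and compound 3 both give only a limit of the assay in this assay, so the step between them cannot be read. The compounds shown leave open the actual concentration at which compound 1, compound 2 or compound 3 reaches the half-maximal effect.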